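Swapping the aryl ether head for a plain aminophenyl

The source may report more compounds than this note shows. Statements on the series, on what has been measured and on what is new or still open speak of the compounds shown alone.

Of the compounds shown here, three of a shared core have been measured in a functional assay (aorta) with Oryctolagus cuniculus as the target; a lower number here means tighter binding, a higher number weaker binding. Compound 1 `COc1cc(C(C)=O)ccc1OCCCN1CCC(C(c2ccccc2)c2ccc(F)cc2)CC1` gives 6.31 nM, compound 2 `COc1cc(C(C)=O)ccc1OCCCN1CCC(C(c2ccc(C)cc2)c2ccc(C)cc2)CC1` gives 15.9 nM, and compound 3 `COc1cc(C(C)O)ccc1OCCCN1CCC(C(c2ccc(F)cc2)c2ccc(F)cc2)CC1` gives 10 nM. The three numbers sit close together: compound 3 lies nearest to compound 1 and furthest from compound 2, yet both of these gaps stay within the usual scatter of this assay, so no ordering among the three can be read from them.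

Compound 4 `Nc1ccc(OCCCN2CCC(C(c3ccc(F)cc3)c3ccc(F)cc3)CC2)cc1` is the unmeasured one. Its difference from compound 3 is 4-aminophenyl in place of 4-(1-hydroxyethyl)-2-methoxyphenyl on an oxygen on a saturated carbon. The head group that leaves carries two oxygens and a second ring substituent, while the head group that enters is smaller and carries a single nitrogen. Going by the values given here, no pair of measured compounds differs in this place, so there is nothing directly comparable to lean on.

Given the absence of any guiding step, compound 4 is expected to give about 20 nM, with a plausible range from 5 nM to 80 nM. The step of a 2.0-fold higher number from compound 3 to compound 4 (0.30 log units; within the scatter) is expected to be a modest rise in the number, small enough that it could fall within the scatter.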

Compound 4, dissociation constant: 31.6 nM
Beside the measured number, compound 4's estimate is 1.6-fold (0.20 log units) below it; the range from low to high includes it.
By their numbers in this assay, from the lowest: compounds 1, 3, 2 and 4 (each within the scatter of the next, the first and the last beyond it).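

Exchanging the 4-(1-hydroxyethyl)-2-methoxyphenyl head for 4-aminophenyl, on the oxygen at the end of the chain, gives a 3.2-fold higher number from compound 3 to compound 4 (0.50 log units; beyond the scatter) in this assay. Going by these compounds alone, this is the first step that can be read at all, and it shows that this place on the shared core is not indifferent to what sits there, although the effect is modest and compound 4 still gives 31.6 nM, so a much smaller head carrying a nitrogen instead of two oxygens is tolerated without a collapse in the number. Nothing available here explains why the number rises with this exchange.

The step changes several things at once: the methoxy group and the 1-hydroxyethyl group both leave while the amine enters, so the compounds shown cannot say which of these accounts for the rise. A plain phenyl head, or an acetamide in place of the amine, would help separate the loss of the old groups from the arrival of the new one.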